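The compounds below may be only part of what the source reports. "The series", "measured", "known", "first", "only" and "open" are said of these compounds alone.

Compound 1 `CC(CC(=O)O)CC(=O)c1c(CCCCCCc2ccccc2)n(C)c2ccc(Cl)cc12` gives the lowest number of the three measured compounds in a functional assay for antagonist activity at Oxoeicosanoid receptor 1 (Homo sapiens), read by fluorescence and calcium flux, with stated times of 2 min and 1 min; a higher number here means a weaker inhibitor, a lower number a stronger inhibitor: compound 1 shows 0.28 nM. Compound 2 `C[C@H](CC(=O)O)CC(=O)c1c([C@@H](O)CCCCCc2ccccc2)n(C)c2ccc(Cl)cc12`, which carries a hydroxyl on the chain as well as a drawn configuration on the acid-bearing branch, gives 0.38 nM in this assay, a number within the scatter of that for compound 1. Compound 3 `C[C@@H](CC(=O)O)CC(=O)c1c(CCCCCCc2ccccc2)n(C)c2ccc(Cl)cc12` gives 23 nM. Within the data shown here, the only single-place step among the measured compounds runs an 82-fold higher number from compound 1 to compound 3 (1.91 log units; beyond the scatter), and the size of that step is tied to the drawing of the two structures because of the fact that one of compounds 1 and 3 is drawn with a defined configuration and the other without, at the place where they differ.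

Compound 4 `CC(CC(=O)O)CC(=O)c1c(CCCCCc2ccccc2)n(C)c2ccc(Cl)cc12` is the not yet measured compound. It differs from compound 1 in the saturated chain alone: phenyl in place of benzyl on a saturated chain carbon, five bonds along the chain from an aromatic carbon. No measured step among these compounds changes the chain length, so nothing here gives a direct reading of what such a shortening does in this assay. The step from compound 1 to compound 3 concerns a different place and does not bear on it. With no guidance, a modest loss in this assay is expected, but with wide uncertainty, so the estimated step is a 3.6-fold higher number from compound 1 to compound 4 (0.55 log units; beyond the scatter). Compound 4 is accordingly expected to give about 1 nM in this assay, within a range of 0.2 nM to 6 nM.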

Compound 4, half-maximal inhibitory concentration: 11 nM
Beside the measured number, compound 4's estimate is 11-fold (1.04 log units) below it, and the stated range ends below it.
By their numbers in this assay, from the lowest: compounds 1 and 2 (each within the scatter of the next); then compound 4; then compound 3.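

In this assay, the saturated chain of compound 1 proves to be a place where a single change has a large effect: a 39-fold higher number from compound 1 to compound 4 (1.59 log units; beyond the scatter) is the reading for phenyl in place of benzyl on a saturated chain carbon, five bonds along the chain from an aromatic carbon. Among these compounds, until now the only single-place step concerned a stereocentre at a saturated chain carbon, whereas compound 1 and compound 4 are both drawn without a configuration there, so this step is the first reading of a change in the chain itself, and it lies beyond the scatter. No evidence given here bears on why this change has so large an effect.

The compounds shown leave open whether a longer chain than that of compound 1 would keep, lower or raise the number, so they give one point on the chain rather than a trend with length. They also leave open how an ether oxygen within the chain, or a fluorine or methoxy group on the terminal phenyl ring, would read in this assay.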